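Compound 1 to compound 4: replacing the aromatic end group

The source may report more compounds than this note shows. Statements on the series, on what has been measured and on what is new or still open speak of the compounds shown alone.

Measured in a functional assay on K562 cells (Homo sapiens) for inhibition, read by MTT assay, with a stated time of 48 h; on this read-out lower numbers stand for stronger inhibition and higher numbers for weaker inhibition:
- compound 1 `O=C(Nc1ccc(-c2cn([C@@H]3CN[C@H](C(=O)Nc4ccc(Cl)c(C(F)(F)F)c4)C3)nn2)cn1)C1CC1`: 8770 nM
- compound 2 `CC(C)(C)OC(=O)N1C[C@@H](n2cc(-c3ccc4c(N)n[nH]c4c3)nn2)C[C@H]1C(=O)Nc1ccc(Cl)cc1Cl`: 12200 nM
- compound 3 `CC(=O)Nc1n[nH]c2cc(-c3cn([C@@H]4CN[C@H](C(=O)Nc5ccc(Cl)c(C(F)(F)F)c5)C4)nn3)ccc12`: 15500 nM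

Compound 1 stands within the usual scatter of both other compounds, so this assay does not separate it from either. Within the data shown here, the three values also lie within the scatter of one another, and no compound in this set can be ranked.

Compound 4 `Nc1nc2ccc(-c3cn([C@@H]4CN[C@H](C(=O)Nc5ccc(Cl)c(C(F)(F)F)c5)C4)nn3)nc2s1` is the next compound to be read, and it departs from compound 1 at a single place. The 6-((cyclopropylcarbonyl)amino)pyridin-3-yl group is replaced on an aromatic carbon of a five-membered aromatic ring with 3 nitrogen: a group of 10 heavy atoms (6 carbon, 3 nitrogen, 1 sulfur; one five-membered aromatic ring with 2 hetero atoms, one six-membered aromatic ring with 1 hetero atom) in place of a group of 12 heavy atoms (9 carbon, 2 nitrogen, 1 oxygen; one three-membered non-aromatic ring of carbon only, one six-membered aromatic ring with 1 hetero atom), on an aromatic carbon.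

Among the measured compounds shown here, no measured compound carries the entering group, and no single-place step between measured compounds is available, so the size of this step cannot be read directly. For the measured compounds named here, the only guide is the narrow spread of the values, with compound 1 at 8770 nM and compound 3 at 15500 nM. No step beyond the scatter is therefore expected in this assay, and no direction is favoured with confidence.

The expected change is a 1.1-fold higher number from compound 1 to compound 4 (0.06 log units; within the scatter).

For compound 4 the estimated value is 10000 nM, with an expected range of 3000 nM to 30000 nM.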

Compound 4, half-maximal inhibitory concentration: 26200 nM
Compound 4: middle estimate off by 2.6-fold (0.42 log units), on the low side; measured number inside the range.
By their numbers in this assay, from the lowest: compounds 1, 2, 3 and 4 (each within the scatter of the next, the first and the last beyond it).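

In this assay, among these compounds, replacing the 6-((cyclopropylcarbonyl)amino)pyridin-3-yl group on the aromatic carbon of the five-membered aromatic ring with 3 nitrogen gives a 3.0-fold higher number from compound 1 to compound 4 (0.48 log units; beyond the scatter), the first single-place step and one that lies beyond the scatter. This place is therefore not indifferent to the group it carries: the entering group, with its five-membered aromatic ring containing sulfur, weakens inhibition modestly relative to the group that leaves. Nothing measured on these compounds accounts for the step, and the whole end group changes at once, so the contribution of any one part of it cannot be isolated.

It remains open whether a group at this place can bring the number below that of compound 1, at 8770 nM, and all the compounds shown carry a fused or amide-bearing aromatic end group. A plain phenyl ring, a pyridin-3-yl group carrying a free amine, or the same pyridin-3-yl group with an acetyl in place of the cyclopropylcarbonyl would show whether the pyridine ring or the cyclopropyl amide matters more here.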